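Ring contraction on the amide side chain: cytotoxicity notes

The source may hold more compounds than are shown below. What is called first, only, known or untested is meant among the compounds shown, and "the series" means these compounds.

Compound 1 `O=C(CN1CCCCC1)Nc1ccc(-c2nc3cc(Cl)c(Cl)cc3[nH]2)cc1` carries a piperidin-1-yl on a saturated chain carbon bound to a carbonyl carbon. In an ADME assay on Vero cells (Chlorocebus sabaeus) for cytotoxicity (on this read-out lower numbers stand for higher toxicity in this test and higher numbers for lower toxicity in this test), compound 1 gives only a limit, > 100000 nM, so no number is known for it. Compound 2 `O=C(CN1CCCC1)Nc1ccc(-c2nc3cc(C(F)(F)F)ccc3[nH]2)cc1` is the pyrrolidin-1-yl analogue on a different core, and in this assay compound 2 also reaches only a limit, > 100000 nM. Compound 3 `COc1cccc(-c2nc3cc(C(F)(F)F)ccc3[nH]2)c1` lacks the amide side chain altogether, and in this assay compound 3 likewise gives a limit, > 100000 nM. For the measured compounds named here, every value shown therefore rests at the limit of > 100000 nM in this assay, at which 3 of the 3 values shown sit, and no step between measured compounds can be read out; the set so far shows no gradient at all.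

Compound 4 `O=C(CN1CCCC1)Nc1ccc(-c2nc3cc(Cl)c(Cl)cc3[nH]2)cc1` is built from compound 1 by the change (pyrrolidin-1-yl in place of piperidin-1-yl on a saturated chain carbon bound to a carbonyl carbon). The same ring change is seen between compound 1 and compound 2, both at the limit, which gives no hint of a shift in either direction. The step from compound 1 to compound 4 in this assay is expected to be none beyond the scatter, a step that the limit leaves unreadable from compound 1 to compound 4. Compound 4 is therefore expected to sit at about 120000 nM, within 60000 nM to 250000 nM, most likely again as a limit only.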

Compound 4, half-maximal cytotoxic concentration: > 100000 nM
Compound 4 gave a limit, no number; the forecaster's own chance of this, stated with the estimate: 85%; the middle value does not contradict the limit.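

Compound 4, like compound 1, gives only a limit in this assay, so no step from compound 1 to compound 4 can be read: the limit of > 100000 nM in this assay, at which 4 of the 4 values shown sit.

The compounds shown leave open whether pyrrolidin-1-yl in place of piperidin-1-yl on a saturated chain carbon bound to a carbonyl carbon changes the read-out at all, and at what concentration any compound shown would reach the half-maximal cytotoxic effect in this assay.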